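The source may report more compounds than this note shows. Statements on the series, on what has been measured and on what is new or still open speak of the compounds shown alone.

Of the compounds shown here, three sharing one core have been read in a functional assay on SH-SY5Y cells (Homo sapiens) for cytotoxicity, read by MTT assay, with a stated time of 48 h; a lower number here means a stronger inhibitor, a higher number a weaker inhibitor. Compound 1 `COc1cc(/C=C/C(=O)/C=C/c2nc3ccccc3n2C)ccc1O` gives 4700 nM, compound 2 `COc1cc(/C=C/C(=O)/C=C/c2nc3cc(C)ccc3n2C)ccc1O` gives 4700 nM, and compound 3 `COc1cc(/C=C/C(=O)/C=C/c2nc3cc(Cl)ccc3n2C)ccc1O` gives 4700 nM, so compound 3 stands level with the other two at the digits reported.

The step now in question leads from compound 3 to compound 4 `COc1cc(/C=C/C(=O)/C=C/c2nc3cc(O)ccc3n2C)ccc1O`. It is hydroxy in place of chloro on an aromatic carbon, on a six-membered aromatic ring of carbon only that is part of a fused or bridged system of two rings: hydroxy in place of chloro on an aromatic carbon.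

Within the data shown here, three measured steps bear on this change. Methyl in place of hydrogen gave no change at the digits printed from compound 1 to compound 2 (within the scatter), chloro in place of hydrogen gave no change at the digits printed from compound 1 to compound 3 (within the scatter), and chloro in place of methyl gave no change at the digits printed from compound 2 to compound 3 (within the scatter). Among the measured compounds shown here, none of these steps brings in a hydroxy, so the data offer no direct precedent and the expectation rests on this flat run alone. The expected step in this assay is therefore no change at the digits printed from compound 3 to compound 4 (within the scatter), which means none beyond the scatter, with neither direction favoured. For compound 4 the estimated value is 4700 nM, with an expected range from 2200 nM to 10000 nM.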

Compound 4, half-maximal inhibitory concentration: 4800 nM
Beside the measured number, compound 4's estimate is 1.0-fold (0.01 log units) below it, and the stated range covers the measured number.
By their numbers in this assay, from the lowest: compounds 1, 2, 3 and 4 (each within the scatter of the next).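

In this assay, the step to hydroxy puts on this aromatic carbon a group counted with a hydrogen-bond donor and a hydrogen-bond acceptor, where chloro has neither, yet all three new steps stay within the scatter: a 1.0-fold higher number from compound 3 to compound 4 (0.01 log units; within the scatter), a 1.0-fold higher number from compound 2 to compound 4 (0.01 log units; within the scatter) and a 1.0-fold higher number from compound 1 to compound 4 (0.01 log units; within the scatter). The earlier compounds shown here showed only that hydrogen, methyl and chloro could not be told apart here; with compound 4, hydroxy joins them, so across these four compounds this assay does not separate any of the groups at this position. No measurement offered here accounts for this insensitivity.

From the compounds shown here alone, whether an amine, a carboxylic acid or a longer chain on the same carbon would also read level with these four compounds remains open, as does whether hydroxy on another carbon of that ring would do so. All four compounds also keep the rest of the shared core unchanged, so they cannot say whether replacing the methoxy or the hydroxy on its other aromatic ring would move the reading in this assay.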